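Shortening the Chain on a Series at the Limit

The compounds below may be only part of what the source reports. "The series", "measured", "known", "first", "only" and "open" are said of these compounds alone.

Three measured compounds share one core and differ only in the group on an aromatic nitrogen. Compound 1 carries isopropyl there, `CC(C)n1c(=O)n(C(=O)NCCN2CCN(C)CC2)c2ccccc21`. In a functional assay for antagonist activity at 5-hydroxytryptamine receptor 4 (Cavia porcellus) (on this read-out lower numbers stand for lower potency and higher numbers for higher potency (the scale is a negative logarithm)), compound 1 gives only a limit, < 6. Compound 2 adds a fluorine and an amine on the ring, `CC(C)n1c(=O)n(C(=O)NCCN2CCN(C)CC2)c2cc(F)c(N)cc21`. In this assay compound 2 likewise reaches only a limit, < 6. Compound 3 carries butyl, `CCCCn1c(=O)n(C(=O)NCCN2CCN(C)CC2)c2ccccc21`. In this assay compound 3 also sits at a limit, < 6. So compound 3 stands where every measured value stands, (the limit of < 6 in this assay, at which 3 of the 3 values shown sit), and the step that the two limits leave unreadable from compound 1 to compound 3 cannot be read from two limits.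

Compound 4 is `CCCn1c(=O)n(C(=O)NCCN2CCN(C)CC2)c2ccccc21`, made from compound 3 by hydrogen in place of methyl on a saturated chain carbon, three bonds along the chain from an aromatic nitrogen. Among the measured compounds shown here, no measured step speaks to this change; the only step that exists has no readable size. All measured values sit at one limit (the limit of < 6 in this assay, at which 3 of the 3 values shown sit), so compound 4 is expected to remain there, and its step that the limit leaves unreadable from compound 3 to compound 4 is expected to be none beyond the scatter. Compound 4 is estimated at 5.5, in the range 4.7 to 6.2, most likely reported once more as a limit.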

Compound 4, negative logarithm of the antagonist equilibrium constant: < 6
Compound 4 gave a limit, no number; the forecaster's own chance of this, stated with the estimate: 85%; the middle value lies beyond the limit too.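

Compound 4 gives only a limit, < 6, and the steps to it from compound 1 and from compound 3 cannot be read. The compounds shown leave open whether the group on the aromatic nitrogen changes potency in this assay at all, as every value stands together: the limit of < 6 in this assay, at which 4 of the 4 values shown sit.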